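Two Methyl Groups Added to the Phenyl of Compound 3

A few compounds are considered here, and "the series" means these few. Any claim that something is new, unique, unknown or untested is made for them only; others in the source may bear on it.

Of the compounds shown here, three have so far been measured in a functional assay on the whole organism (strain CD-1) for inhibition, with Mus musculus as the target, in the writhing test, with stated times of 15 min and 20 min, at a dose of 10 mg/kg by the subcutaneous route; a higher number here means more inhibition at the dose given (going by the name of the read-out), a lower number less inhibition. Compound 1, `N#C/C(=C\c1ccc(O)c(O)c1)C(=O)NC/C=C/c1ccccc1`, gives 12.3% in this assay. Compound 2, `N#C/C(=C\c1ccc(O)c(O)c1)C(=O)CC/C=C/c1ccccc1`, gives 15%. Compound 3, `N#C/C(=C\c1ccccc1)C(=O)OC/C=C/c1ccccc1`, gives 25.1%, the highest of the three numbers; its nearest neighbour is compound 2, whose number lies lower by a margin beyond the scatter, and compound 1 lies further below it, also beyond the scatter. No two of these compounds differ in a single place, so no single-point step has been measured among them, and compound 3 stands alone at the top on its own number.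

Compound 4, `Cc1ccc(/C=C(\C#N)C(=O)OC/C=C/c2ccccc2)cc1C`, is the next compound to be tested in this assay. Its relation to compound 3 is a single change: 3,4-dimethylphenyl in place of phenyl on a double-bonded chain carbon bound to a double-bonded chain carbon. No comparable change has been measured here, so there is nothing to show whether two methyl groups on that ring raise or lower the inhibition. On that basis the step is expected to be small. Compound 4 is expected to give about 27% in this assay, with a range from 12% to 42%. The estimated step of a number 1.9 percentage points higher from compound 3 to compound 4 (within the scatter) is therefore expected to stay within the usual scatter, with no direction favoured.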

Compound 4, a percentage reported as inhibition, in the whole organism at one dose (the size of the read-out at that dose, not a potency): 18.4%
Compound 4: middle estimate off by 8.6 percentage points, on the high side; low and high end bracket the measured number.
By their numbers in this assay, from the lowest: compounds 1, 2, 4 and 3 (each within the scatter of the next, the first and the last beyond it).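

In this assay, for the compounds shown here, the pair gives the first single-place step in this set, a number 6.7 percentage points lower from compound 3 to compound 4 (within the scatter), with 3,4-dimethylphenyl in place of phenyl on a double-bonded chain carbon bound to a double-bonded chain carbon. The earlier compounds shown here, none of which differ in one place, could not speak to any single position, whereas this pair shows that two added methyl groups on this ring leave the inhibition at the given dose indistinguishable from that of the unsubstituted phenyl, within the usual scatter of the measurement. Nothing in hand bears on why the number reads as it does at this position.

The compounds shown leave open whether a group of another kind on this ring, such as an amine or a carboxylic acid, would shift the number beyond the scatter, and whether a single methyl group would read like the pair. They also leave open whether 3,4-dimethylphenyl would read the same way on a core with an amide in place of the ester.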